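Swapping the thiocyanate for bromine on the shared core

This account rests on a few compounds, and the source may have more. Where it says the series, first, only, none or still open, it means among the compounds named here.

Measured so far:
Compound 1 `COC(=O)c1ccc(-c2noc(CCl)n2)cc1`: 14200 nM
Compound 2 `COC(=O)c1ccc(-c2noc(CSC#N)n2)cc1`: 43700 nM

Of the compounds shown here, two have been measured in an ADME assay on MT2 cells (Homo sapiens) for cytotoxicity, read by XTT assay, with a stated time of 4 days; on this read-out lower numbers stand for higher toxicity in this test and higher numbers for lower toxicity in this test. Compound 1 `COC(=O)c1ccc(-c2noc(CCl)n2)cc1` gives 14200 nM, and compound 2 `COC(=O)c1ccc(-c2noc(CSC#N)n2)cc1` gives 43700 nM. Among the measured compounds shown here, compound 2 therefore stands with the highest of the two numbers, that is, the lower toxicity in this test, and the single step of a 3.1-fold higher number from compound 1 to compound 2 (0.49 log units; beyond the scatter) separates it from compound 1.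

Compound 3 `COC(=O)c1ccc(-c2noc(CBr)n2)cc1` has not yet been measured. It differs from compound 2 in one place: bromo in place of cyanosulfanyl on a saturated chain carbon bound to an aromatic carbon. For the measured compounds named here, the only measured step that bears on this change is the one from compound 1 to compound 2, in which a halogen on the same saturated chain carbon gave way to cyanosulfanyl and the number rose, a 3.1-fold higher number from compound 1 to compound 2 (0.49 log units; beyond the scatter). Compound 3 reverses that kind of change, putting a single halogen atom back in place of cyanosulfanyl, so the number is expected to fall by about the same amount, a 4.4-fold lower number from compound 2 to compound 3 (0.64 log units; beyond the scatter). On that basis compound 3 is estimated at 10000 nM, with a range from 3000 nM to 30000 nM.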

Compound 3, half-maximal cytotoxic concentration: 32700 nM
Compound 3: the middle estimate sits 3.3-fold (0.51 log units) below what was measured; measured number outside the range, above it.
By their numbers in this assay, from the lowest: compound 1; then compounds 3 and 2 (each within the scatter of the next).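

In this assay, bromo in place of cyanosulfanyl on a saturated chain carbon bound to an aromatic carbon gives a 1.3-fold lower number from compound 2 to compound 3 (0.13 log units; within the scatter) and so leaves these two groups indistinguishable at this place. Bromo in place of chloro at the same place gives a 2.3-fold higher number from compound 1 to compound 3 (0.36 log units; beyond the scatter) and shows that the two halogens are not interchangeable here, with compound 1 alone set apart by the lowest number, meaning the higher toxicity in this test. The earlier step could be read as a halogen on this carbon going with a low number, but compound 3 carries a halogen and goes against that reading, so the pattern belongs to chloro in compound 1 rather than to halogens as a class.

No measured evidence here accounts for these differences. From the compounds shown here alone, it also remains open whether an iodo group, an amine or a hydroxyl group on this same carbon would sit with compound 1 or with compound 2 and compound 3, and whether the pattern holds when the shared core carries a carboxylic acid.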